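Sulfonyl-to-carbonyl swap on the anilide nitrogen

This account rests on a few compounds, and the source may have more. Where it says the series, first, only, none or still open, it means among the compounds named here.

Three sulfonamides share one core. Compound 1 `COc1cc(N(Cc2nc3ccccc3[nH]2)S(=O)(=O)c2ccc(Br)cc2)cc(OC)c1OC` gives 6890 nM in a functional assay on PC-3 cells (Homo sapiens) for inhibition, read by MTT assay, with a stated time of 48 h; a higher number here means a weaker inhibitor, a lower number a stronger inhibitor. Compound 2 `COc1cc(N(Cc2nc3ccccc3[nH]2)S(=O)(=O)c2ccccc2Cl)cc(OC)c1OC` gives 34500 nM in this assay, and compound 3 `COc1ccc(S(=O)(=O)N(Cc2nc3ccccc3[nH]2)c2cc(OC)c(OC)c(OC)c2)cc1OC` gives 30400 nM. Compound 2 holds the highest of the three numbers: its step from compound 1 is a 5.0-fold higher number from compound 1 to compound 2 (0.70 log units; beyond the scatter), while compound 3 sits within the scatter of it, a 1.1-fold lower number from compound 2 to compound 3 (0.05 log units; within the scatter). The third measured step, a 4.4-fold higher number from compound 1 to compound 3 (0.64 log units; beyond the scatter), also runs away from compound 1.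

Compound 4 `COc1cc(N(Cc2nc3ccccc3[nH]2)C(=O)c2ccc(C)cc2)cc(OC)c1OC` is not yet measured. Against compound 2 the change is (4-methylphenyl)carbonyl in place of (2-chlorophenyl)sulfonyl on a nitrogen on an aromatic ring. Every measured step here varies only the aromatic ring on the sulfonyl sulfur and moves the number by a modest amount; none replaces the sulfonyl group itself by a carbonyl, and none puts a 4-methylphenyl ring in place. The measured steps therefore bear on this change only loosely, and the expectation rests on their modest size. The estimated step is a 1.7-fold lower number from compound 2 to compound 4 (0.24 log units; within the scatter), with no clear direction beyond the scatter. Compound 4 is expected to give about 20000 nM in this assay, estimated within 4000 nM to 80000 nM.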

Compound 4, half-maximal inhibitory concentration: 42000 nM
The estimate for compound 4 lay 2.1-fold (0.32 log units) below the measured number; low and high end bracket the measured number.
By their numbers in this assay, from the lowest: compound 1; then compounds 3, 2 and 4 (each within the scatter of the next).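

Going by these compounds alone, compound 4 gives the first direct look at a carbonyl in place of the sulfonyl group on this nitrogen. In this assay, (4-methylphenyl)carbonyl in place of (2-chlorophenyl)sulfonyl gives a 1.2-fold higher number from compound 2 to compound 4 (0.09 log units; within the scatter), so this exchange leaves the number within the scatter of compound 2. Against (4-bromophenyl)sulfonyl, the same carbonyl group gives a 6.1-fold higher number from compound 1 to compound 4 (0.79 log units; beyond the scatter), which places compound 1 apart from compound 4 as well as from compound 2 and compound 3. Nothing at hand gives a cause for either step.

In compound 4 the linking group and the ring substituent change together, so their separate contributions remain unresolved; a (4-bromophenyl)carbonyl group on this nitrogen would bear directly on that. Also open, as far as these compounds go, is how the number would respond to a ring carrying an amine or a carboxylic acid on the sulfonyl or carbonyl group.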